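Chloro for bromo on the shared core of compound 1

The source may report more compounds than this note shows. Statements on the series, on what has been measured and on what is new or still open speak of the compounds shown alone.

Compound 1, `Brc1cccc2c1nnn2CC1CC1`, stands lowest of the two numbers available in an ADME assay on microsomes from liver (Homo sapiens) for metabolic stability, tested at 2.5 uM (a higher number here means faster removal of the compound, a lower number slower removal), giving 1.3 mL/min/g. Among the measured compounds shown here, its nearest neighbour is compound 2, `CCCn1nnc2c(Br)cccc21`, which in this assay gives 4.7 mL/min/g; the step between them, a 3.6-fold higher number from compound 1 to compound 2 (0.56 log units; beyond the scatter), is the only measured step in the set with a single change. Compound 3, `Cn1nnc2c(Br)cccc21`, has no number in this assay; its entry reads "not determined" (no result reported).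

The next compound, compound 4, `Clc1cccc2c1nnn2CC1CC1`, differs from compound 1 by chloro in place of bromo on an aromatic carbon. For the measured compounds named here, no measured step shares this change: the step from compound 1 to compound 2 concerns the group on the saturated chain carbon bound to the aromatic nitrogen and leaves the halogen untouched, and compound 3 contributes no number. The halogen exchange is therefore unsupported by any measured pair in the series, and the working assumption is that it moves the number in this assay by no more than the scatter, in no preferred direction.

Compound 4 is accordingly expected to give about 1.3 mL/min/g in this assay, with a range from 0.6 mL/min/g to 2.8 mL/min/g. The step this estimate implies, no change at the digits printed from compound 1 to compound 4 (within the scatter), is expected to stay within the scatter.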

Compound 4, intrinsic clearance in a liver preparation (reported as CLH), per the amount of preparation that the assay uses: 4.2 mL/min/g
Estimate against measurement, compound 4: 3.2-fold (0.51 log units) below; measured number above the stated range.
By their numbers in this assay, from the lowest: compound 1; then compounds 4 and 2 (each within the scatter of the next).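

In this assay the aromatic carbon that carries the halogen proves sensitive to a small exchange: chloro in place of bromo gives a 3.2-fold higher number from compound 1 to compound 4 (0.51 log units; beyond the scatter), although one heavy atom replaces one heavy atom and neither group brings a ring, a hydrogen-bond donor, a hydrogen-bond acceptor or a net charge. Until now the only readable change lay in the group on the saturated chain carbon bound to the aromatic nitrogen, with a 3.6-fold higher number from compound 1 to compound 2 (0.56 log units; beyond the scatter), so the lowest number among these compounds now belongs to the one compound that combines bromo with cyclopropyl, and altering either place gives a step beyond the scatter. Nothing available here accounts for the size of the halogen step.

Whether bromo is unusual at this aromatic carbon or chloro is the outlier remains open, since only these two halogens are shown there, and fluoro, methyl or methoxy at the same place would help settle it. Also open, as far as these compounds go, is whether the chloro for bromo step keeps its size and direction when ethyl stands in place of cyclopropyl on the chain carbon.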